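Furan-2-yl to furan-3-yl: from compound 2 to compound 3

A few compounds are considered here, and "the series" means these few. Any claim that something is new, unique, unknown or untested is made for them only; others in the source may bear on it.

In a functional assay on HL-60 cells (Homo sapiens) for antiproliferative activity, read by XTT assay, with a stated time of 72 h (a higher number here means a weaker inhibitor, a lower number a stronger inhibitor), compound 1 (`CSc1ncnc2c1c(-c1ccoc1)cn2[C@@H]1O[C@H](CO)[C@@H](O)[C@H]1O`) gives 360 nM and compound 2 (`CNc1ncnc2c1c(-c1ccco1)cn2[C@@H]1O[C@H](CO)[C@@H](O)[C@H]1O`) gives 620 nM. Compound 2 has the higher of the two numbers, but the two values lie within the usual scatter of each other, so the pair does not separate.

The next compound is compound 3 (`CNc1ncnc2c1c(-c1ccoc1)cn2[C@@H]1O[C@H](CO)[C@@H](O)[C@H]1O`). It has furan-3-yl in place of furan-2-yl on an aromatic carbon of the shared core, and the two structures have the same atoms, joined differently: furan-3-yl in place of furan-2-yl on an aromatic carbon.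

For the measured compounds named here, no measured pair differs in this one place, so the size of this step cannot be read from the data. Going by the values given here, the only guide is compound 1, which also carries furan-3-yl and gives 360 nM. A small shift towards a lower number is therefore expected in this assay, not beyond the scatter. The expected step is a 1.4-fold lower number from compound 2 to compound 3 (0.16 log units; within the scatter). Compound 3 is estimated at 430 nM, with an expected range of 150 nM to 1200 nM.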

Compound 3, half-maximal inhibitory concentration: > 15000 nM
Compound 3 ended at the assay's limit (the forecaster's own chance of this, stated with the estimate: 3%); at least 34-fold (1.54 log units) between middle value and limit.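

In this assay compound 3 gives > 15000 nM, which is a limit of the assay and not a number. Each of the two single changes leading to compound 3 is large: furan-3-yl in place of furan-2-yl on an aromatic carbon gives an at least 24-fold higher number from compound 2 to compound 3 (1.38 log units; beyond the scatter), and methylamino in place of methylsulfanyl on an aromatic carbon gives an at least 41-fold higher number from compound 1 to compound 3 (1.61 log units; beyond the scatter). The earlier compounds shown here did not show this sensitivity: furan-3-yl is compatible with a measurable value alongside methylsulfanyl in compound 1 and furan-2-yl alongside methylamino in compound 2, so within these three compounds neither group alone settles the outcome, and the loss appears only where furan-3-yl and methylamino occur together.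

On these data alone, how far compound 3 lies beyond the limit stays unknown, so both steps give only a minimum size: the limit of > 15000 nM in this assay, at which 1 of the 3 values shown sits. Also open are how furan-2-yl would read together with methylsulfanyl, which would complete the comparison of the two places, and how a dimethylamino group or a thiophen-3-yl ring would read at these places.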